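Phenyl in place of benzyl on the amide-type nitrogen

The source may report more compounds than this note shows. Statements on the series, on what has been measured and on what is new or still open speak of the compounds shown alone.

Compound 2 `Cc1nc(N)sc1CCCN/C(N)=N/C(=O)NCc1ccccc1` gives 69.2 nM in an assay on membranes from Sf9 cells for displacement of a labelled ligand from histamine H2 receptor (Homo sapiens), read by scintillation counting, with a stated time of 60 min (a lower number here means a stronger inhibitor, a higher number a weaker inhibitor), the larger of the two numbers recorded so far, although compound 1 `Cc1nc(N)sc1CCCN/C(N)=N/C(=O)N[C@@H](C)c1ccccc1` at 51.3 nM sits within the scatter of it, the step being a 1.3-fold higher number from compound 1 to compound 2 (0.13 log units; within the scatter). Compound 3 `Cc1nc(N)sc1CCCN/C(N)=N/C(=O)Nc1ccccc1` is the next member, with phenyl in place of benzyl on an amide-type nitrogen. Within the data shown here, the single measured step that touches this region, a 1.3-fold higher number from compound 1 to compound 2 (0.13 log units; within the scatter), concerns only the methyl on the saturated chain carbon and says nothing about removing that carbon altogether; no measured pair shows phenyl in place of benzyl here. With that thin basis, the expectation for compound 3 in this assay is a step of a 1.6-fold higher number from compound 2 to compound 3 (0.20 log units; within the scatter) toward a weaker inhibitor, with the direction itself uncertain. Compound 3 is therefore estimated at 110 nM, the range running from 30 nM to 400 nM.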

Compound 3, inhibition constant: 3160 nM
The estimate for compound 3 lay 29-fold (1.46 log units) below the measured number, and the stated range ends below it.
By their numbers in this assay, from the lowest: compounds 1 and 2 (each within the scatter of the next); then compound 3.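

In this assay, phenyl in place of benzyl on the amide-type nitrogen gives a 46-fold higher number from compound 2 to compound 3 (1.66 log units; beyond the scatter) and phenyl in place of 1-phenylethyl gives a 62-fold higher number from compound 1 to compound 3 (1.79 log units; beyond the scatter); at this position the aromatic ring set directly on the nitrogen is therefore far weaker than either ring held on a saturated chain carbon. The methyl on that carbon had shown no effect beyond the scatter (a 1.3-fold higher number from compound 1 to compound 2 (0.13 log units; within the scatter)), so the large step appears only when the carbon itself is gone. Nothing available here bears on the reason for this loss.

Open, on these data alone, is whether a longer chain, such as 2-phenylethyl, on the same nitrogen holds the level of compound 2 or moves beyond it. Also open, as far as these compounds go, is whether a chlorine or methoxy group on the phenyl of compound 3 recovers any of the loss.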